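This account rests on a few compounds, and the source may have more. Where it says the series, first, only, none or still open, it means among the compounds named here.

Compound 1 `Cn1ccc2ccc(-c3cc(Nc4ccccc4S(N)(=O)=O)cc4nccnc34)cc21` carries a sulfonamide with a free nitrogen; in an assay for inhibition of 6-phosphofructo-2-kinase/fructose-2,6-bisphosphatase 3 (Homo sapiens), read by ADP-Glo, with a stated time of 2 h (on this read-out higher numbers stand for weaker inhibition and lower numbers for stronger inhibition), compound 1 gives 265 nM. Within the data shown here, compound 2 `CN1CCCC(NS(=O)(=O)c2ccccc2Nc2cc(-c3ccc4ccn(C)c4c3)c3nccnc3c2)C1` places a 1-methylpiperidin-3-yl group on that sulfonamide nitrogen, and in this assay compound 2 gives 59 nM, the lowest of the two numbers measured so far, reached through the step of a 4.5-fold lower number from compound 1 to compound 2 (0.65 log units; beyond the scatter), which is the only measured step in this set. Compound 3 `CN1CCC(NS(=O)(=O)c2ccccc2Nc2cc(-c3ccc4ccn(C)c4c3)c3nccnc3c2)C1` differs from compound 2 by 1-methylpyrrolidin-3-yl in place of 1-methylpiperidin-3-yl on a sulfonamide nitrogen. Among the measured compounds shown here, no measured step covers a swap of one saturated ring for a smaller one, so the only guide is the gain seen in a 4.5-fold lower number from compound 1 to compound 2 (0.65 log units; beyond the scatter) on adding such a ring at all, and compound 3 keeps a ring of that sort in the same place. The expected step of a 1.2-fold higher number from compound 2 to compound 3 (0.07 log units; within the scatter) is therefore small, with no clear direction. Compound 3 is expected to give about 70 nM in this assay, within a range from 25 nM to 200 nM.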

Compound 3, half-maximal inhibitory concentration: 33 nM
For compound 3 the middle estimate is 2.1-fold (0.33 log units) above the measured one; low and high end bracket the measured number.
By their numbers in this assay, from the lowest: compounds 3 and 2 (each within the scatter of the next); then compound 1.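

Swapping the six-membered ring for the five-membered one gives a 1.8-fold lower number from compound 2 to compound 3 (0.25 log units; within the scatter) in this assay, so on this sulfonamide nitrogen the two ring sizes cannot be told apart. Set against hydrogen on the same nitrogen, 1-methylpyrrolidin-3-yl gives an 8.0-fold lower number from compound 1 to compound 3 (0.90 log units; beyond the scatter), which shows that the lower number seen earlier is not tied to 1-methylpiperidin-3-yl alone but appears with a second ring as well. No measurement here offers a reason for this tolerance of either ring.

Still open, on these data alone, is whether the ring nitrogen matters at all: a cyclopentyl ring or an open dimethylaminoethyl chain on the sulfonamide nitrogen would test that. It also remains to be seen whether the methyl on the ring nitrogen counts, which a ring carrying hydrogen there would show.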